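Cyclopentyl for isopropyl on the ring nitrogen: working notes

The source may hold more compounds than are shown below. What is called first, only, known or untested is meant among the compounds shown, and "the series" means these compounds.

Compound 1 `CC(C)n1cnc2c(Nc3ccccc3)nc(NCOCc3ccc(C(=O)Nc4ccccc4N)cc3)nc21` serves as the reference point of the series. In a functional assay on HCT-116 cells (Homo sapiens) for antiproliferative activity, read by CCK-8 assay, with a stated time of 72 h, tested at 8 uM (on this read-out higher numbers stand for a stronger effect at the one concentration tested and lower numbers for a weaker effect), compound 1 gives 18.8%. Compound 3 `CC(C)n1cnc2c(Nc3cccc(Cl)c3)nc(NCOCc3ccc(/C=C/C(=O)Nc4ccccc4N)cc3)nc21` differs from compound 1 in more than one place, and the difference between the two cores is not broken down here. In this assay compound 3 gives 27.9%, which lies within the scatter of the value of compound 1. Compound 2 `Nc1ccccc1NC(=O)/C=C/c1ccc(COCNc2nc(Nc3cccc(Cl)c3)c3ncn(C4CCCC4)c3n2)cc1` is obtained from compound 3 by a single change, (cyclopentyl in place of isopropyl on an aromatic nitrogen), and in this assay compound 2 gives 9.19%. The step of a number 18.7 percentage points lower from compound 3 to compound 2 (beyond the scatter) lies beyond the scatter, whereas the values of compound 2 and compound 1 lie within the scatter of each other.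

Compound 4 `Nc1ccccc1NC(=O)c1ccc(COCNc2nc(Nc3ccccc3)c3ncn(C4CCCC4)c3n2)cc1` has not yet been measured. It is related to compound 1 by the same change, (cyclopentyl in place of isopropyl on an aromatic nitrogen), made at a place described in identical words, so this is the same change seen once before. Among the compounds with values here, the expected step here is a number 13.8 percentage points lower from compound 1 to compound 4 (beyond the scatter), resting on the single precedent a number 18.7 percentage points lower from compound 3 to compound 2 (beyond the scatter). Compound 4 is accordingly estimated at 5%, between 0% and 16%.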

Compound 4, a percentage reported as inhibition, at one concentration (the size of the read-out at that concentration, not a potency): 76.9%
Compound 4: middle estimate off by 71.9 percentage points, on the low side; measured number above the stated range.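

On the core of compound 1, cyclopentyl in place of isopropyl on an aromatic nitrogen gives a number 58.1 percentage points higher from compound 1 to compound 4 (beyond the scatter) in this assay, the opposite direction to the earlier step. The outcome of this change therefore depends on the core carrying it, and a step read on one core in this series cannot be carried over to the other: the same change on two cores in this assay, a number 18.7 percentage points lower (beyond the scatter) from compound 3 to compound 2 and a number 58.1 percentage points higher (beyond the scatter) from compound 1 to compound 4, 76.8 percentage points apart, beyond the scatter of two such steps. Within the data shown here, this does not show which difference between the two cores reverses the step, since they differ in more than one place and each core supplies only one pair, read at one concentration.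

The compounds shown hold only isopropyl and cyclopentyl on that nitrogen, which leaves open how an ethyl or a cyclohexyl group there would read on either core. Also open, going by these compounds, is how the same change reads on a core that carries only one of the differences between the core of compound 1 and the core of compound 3.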